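Removing One Methyl: Does the Same Step Repeat?

The compounds below may be only part of what the source reports. "The series", "measured", "known", "first", "only" and "open" are said of these compounds alone.

Measured compounds:
Compound 1 `COc1cc(OC)c(C(=O)/C=C/c2ccccc2SC)c(OC)c1` gives 0% in a functional assay on HaCaT cells (Homo sapiens), read by fluorescence and BrdU incorporation, with a stated time of 48 h, tested at 25 uM; a lower number here means a stronger effect, a higher number a weaker effect of the compound at the concentration tested.
Compound 2 `COc1cccc(/C=C/C(=O)c2c(OC)cc(OC)cc2OC)c1` gives 0% in this assay.
Compound 3 `COc1cc(O)c(C(=O)/C=C/c2ccccc2SC)c(OC)c1` gives 30% in this assay.

Compound 1 and compound 2 share a core and differ only in the ring on the chain: 3-methoxyphenyl in place of 2-(methylsulfanyl)phenyl on a double-bonded chain carbon bound to a double-bonded chain carbon. This swap gave no change at the digits printed from compound 1 to compound 2 (within the scatter), so the two compounds stand level, together at the bottom of the three numbers.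

Compound 3 is compound 1 with a single small change: hydrogen in place of methyl on an oxygen on an aromatic ring. That change gave a number 30 percentage points higher from compound 1 to compound 3 (beyond the scatter), a modest rise that lies beyond the scatter.

Compound 4 `COc1cccc(/C=C/C(=O)c2c(O)cc(OC)cc2OC)c1` has not yet been measured. It relates to compound 2 exactly as compound 3 relates to compound 1: hydrogen in place of methyl on an oxygen on an aromatic ring. The place of the change is the same in both pairs, so this is the same change on a core that differs only in the ring on the chain.

Because compound 1 to compound 3 gave a number 30 percentage points higher from compound 1 to compound 3 (beyond the scatter), and compound 2 stands level with compound 1, the step from compound 2 to compound 4 is expected to be a number 25 percentage points higher from compound 2 to compound 4 (beyond the scatter). Compound 4 is therefore estimated at 25%, with a likely range from 5% to 50%.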

Compound 4, a percentage reported as activity, at one concentration (the size of the read-out at that concentration, not a potency): 8%
Compound 4: the middle estimate sits 17 percentage points above what was measured; measured number inside the range.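

On the core of compound 2, the change from methoxy to hydroxy gave a number 8 percentage points higher from compound 2 to compound 4 (within the scatter), so in this assay this step cannot be told apart from no change. The same change therefore did not carry over at the same size from one core to the other: the same change on two cores in this assay, a number 30 percentage points higher (beyond the scatter) from compound 1 to compound 3 and a number 8 percentage points higher (within the scatter) from compound 2 to compound 4, 22 percentage points apart, beyond the scatter of two such steps

For these two pairs, then, the step measured on the core with the 2-(methylsulfanyl)phenyl ring is a poor guide to the step on the core with the 3-methoxyphenyl ring, but the data do not show why the two differ or how the change would behave on any further core.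

The compounds shown leave open whether an amine, or a longer chain such as ethoxy, at that same place on the aromatic ring would give a step closer to the larger one or the smaller one. Also open, going by these compounds, is how the change from methoxy to hydroxy would read with a ring on the chain that carries a different group, such as a carboxylic acid.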